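Compound 1 to its bromo analogue: expected distribution shift

The source may report more compounds than this note shows. Statements on the series, on what has been measured and on what is new or still open speak of the compounds shown alone.

For the measured compounds named here, in a physicochemical assay for lipophilicity, at pH 7.4 (on this read-out lower numbers stand for lower lipophilicity and higher numbers for higher lipophilicity), compound 1 (`Cc1[nH]c2ccccc2c(=O)c1C1CCCCC1`) gives 2.45 and stands highest of the two numbers so far. Compound 2 (`Cc1[nH]c2ccccc2c(=O)c1Cc1ccccc1`) gives 1.93 and lies lower, with the gap beyond the scatter. Compound 3 (`Cc1[nH]c2ccccc2c(=O)c1Br`) has not yet been measured. It carries bromo in place of cyclohexyl on an aromatic carbon of the shared core (bromo in place of cyclohexyl on an aromatic carbon). Going by the values given here, no measured pair isolates this kind of change, so the expectation rests on the structural change and on these two readings alone. The reading of compound 2 at 1.93 is taken as a rough guide to where a smaller group than cyclohexyl may fall. A downward move beyond the scatter is expected in this assay and the estimated size is a number 0.65 log units lower from compound 1 to compound 3 (beyond the scatter) for this change. For compound 3 the estimated value is 1.8 with an expected range from 1.4 to 2.2 once measured.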

Compound 3, distribution coefficient: 1.67
Beside the measured number, compound 3's estimate is 0.13 log units above it; the range from low to high includes it.
By their numbers in this assay, from the lowest: compounds 3 and 2 (each within the scatter of the next); then compound 1.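

In this assay, this position now has a direct step: bromo in place of cyclohexyl on the aromatic carbon gives a number 0.78 log units lower from compound 1 to compound 3 (beyond the scatter), a change at this position that the first two compounds could not isolate. Compound 3 and compound 2 stand within the scatter of each other, so two different groups at this position are not separated by this read-out, while both stand apart from compound 1. Nothing measured here bears on the reason for the step.

Open, from the compounds shown here alone, is what an amine, a carboxylic acid or a longer chain would give on this aromatic carbon of the shared core. Also open, going by these compounds, is whether the step from cyclohexyl to bromo would keep its size if the methyl group were replaced by another group.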